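Swapping the Amide Substituent in a Series at the Limit

The source may hold more compounds than are shown below. What is called first, only, known or untested is meant among the compounds shown, and "the series" means these compounds.

Compound 3 `CN(Cc1ccccc1F)C(=O)C1CCN(C(=O)c2ccc(S(C)(=O)=O)c([N+](=O)[O-])c2)CC1` was examined in an assay on isolated protein for inhibition of thyroid hormone receptor beta (Homo sapiens), read by fluorescence polarization; a lower number here means a stronger inhibitor, a higher number a weaker inhibitor. In this assay compound 3 gives > 60000 nM, which is a limit of the assay rather than a number. Its two measured neighbours share that outcome. Compound 1 `CS(=O)(=O)c1ccc(C(=O)N2CCC(C(=O)N3CCc4ccccc4C3)CC2)cc1[N+](=O)[O-]` gives > 60000 nM in this assay, again a limit. Compound 2 `CC(C)N(C(=O)C1CCN(C(=O)c2ccc(S(C)(=O)=O)c([N+](=O)[O-])c2)CC1)C(C)C` gives > 60000 nM in this assay, also a limit. Hence the steps among these three cannot be read: a step that the two limits leave unreadable from compound 1 to compound 2, a step that the two limits leave unreadable from compound 1 to compound 3 and a step that the two limits leave unreadable from compound 2 to compound 3. All three values sit at the same limit (the limit of > 60000 nM in this assay, at which 3 of the 3 values shown sit).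

Compound 4 `CS(=O)(=O)c1ccc(C(=O)N2CCC(C(=O)N3CCc4ccccc43)CC2)cc1[N+](=O)[O-]` differs from compound 3 in one place (2,3-dihydro-1H-indol-1-yl in place of (2-fluorobenzyl)(methyl)amino on a carbonyl carbon). Within the data shown here, the only measured steps that bear on this carbonyl carbon are the three unreadable ones above, none of which yields a size in this assay, and compound 1 already carries 1,2,3,4-tetrahydroisoquinolin-2-yl on a carbonyl carbon without leaving the limit. Compound 4 is therefore expected to remain at the limit as well. The step that the limit leaves unreadable from compound 3 to compound 4 is thus expected to be none that can be read beyond the scatter. The estimate for compound 4 is 100000 nM, with a range from 30000 nM to 400000 nM.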

Compound 4, half-maximal inhibitory concentration: > 60000 nM
Compound 4 ended at the assay's limit; the forecaster's own chance of this, stated with the estimate: 85%; the middle value is on the limit's open side.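

In this assay compound 4 gives > 60000 nM, a limit of the assay. Its steps from compound 1, compound 2 and compound 3 therefore cannot be read, and all four compounds sit together: the limit of > 60000 nM in this assay, at which 4 of the 4 values shown sit.

The compounds shown leave open how strongly any of them inhibits, and whether any substituent on this carbonyl carbon would give a readable value.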